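The source may report more compounds than this note shows. Statements on the series, on what has been measured and on what is new or still open speak of the compounds shown alone.

The three measured compounds, all tested in an assay on THP-1 cells for displacement of a labelled ligand from C-C chemokine receptor type 1 (Homo sapiens); a higher number here means a weaker inhibitor, a lower number a stronger inhibitor:

Compound 1, `CC(C)[C@@H](NC(=O)c1cccc(F)c1)C(=O)N1CCC(c2ccc(Cl)cc2)CC1`, gives 24 nM.
Compound 2, `CC(C)[C@@H](NC(=O)CC1CC1)C(=O)N1CCC(c2ccc(Cl)cc2)CC1`, gives 46 nM.
Compound 3, `Cc1ccccc1C(=O)N[C@@H](C(=O)N1CCC(c2ccc(Cl)cc2)CC1)C(C)C`, gives 32 nM.

All three share the same core and differ only in the group attached to the carbonyl carbon of the amide. Compound 3 sits in the middle of the three numbers: compared with compound 1 the step is a 1.3-fold higher number from compound 1 to compound 3 (0.12 log units; within the scatter), and compared with compound 2 it is a 1.4-fold lower number from compound 2 to compound 3 (0.16 log units; within the scatter). Neither of these reaches beyond the scatter, so on these numbers the three compounds cannot be told apart.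

Compound 4, `CC(C)[C@@H](NC(=O)c1ccc(F)cc1)C(=O)N1CCC(c2ccc(Cl)cc2)CC1`, is the next compound. Its difference from compound 3 is 4-fluorophenyl in place of 2-methylphenyl on a carbonyl carbon.

For the measured compounds named here, the steps that bear on this change are those that swap the group on the carbonyl carbon. From compound 1 to compound 2 the step is a 1.9-fold higher number from compound 1 to compound 2 (0.28 log units; within the scatter); from compound 1 to compound 3 it is a 1.3-fold higher number from compound 1 to compound 3 (0.12 log units; within the scatter). Both swaps, one to an aliphatic group and one to a differently substituted phenyl, left the number within the scatter. Compound 1 already carries a fluorophenyl group and sits at the lower end of the three values. For compound 4 the expected step is therefore a 1.2-fold lower number from compound 3 to compound 4 (0.07 log units; within the scatter), a change not clearly beyond the scatter. The estimated value for compound 4 in this assay is 27 nM, with a range of 12 nM to 65 nM.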

Compound 4, half-maximal inhibitory concentration: 118 nM
Beside the measured number, compound 4's estimate is 4.4-fold (0.64 log units) below it; the whole stated range lies below it.
By their numbers in this assay, from the lowest: compounds 1, 3 and 2 (each within the scatter of the next); then compound 4.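

In this assay, for the compounds shown here, the group on the carbonyl carbon now proves able to shift the number, since replacing 2-methylphenyl with 4-fluorophenyl gives a 3.7-fold higher number from compound 3 to compound 4 (0.57 log units; beyond the scatter) and is the first kind of swap here to reach beyond the scatter. Compound 4 also separates from the compound carrying cyclopropylmethyl, with a 2.6-fold higher number from compound 2 to compound 4 (0.41 log units; beyond the scatter) as the step, and the most telling comparison is between two fluorinated groups: a 4.9-fold higher number from compound 1 to compound 4 (0.69 log units; beyond the scatter) shows that 3-fluorophenyl and 4-fluorophenyl are not interchangeable at this place, even though both contain the same atoms. Nothing available explains why these two groups behave differently.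

The compounds shown leave open whether the higher number belongs to fluorine specifically or to any group at the 4-position of the phenyl ring, a question that 4-chlorophenyl or 4-methylphenyl on the same carbonyl carbon could help settle. They also leave open how 2-fluorophenyl would compare, which would show whether the 2-methylphenyl result carries over to a fluorinated phenyl group.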